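Series notes: benzoyl thiosemicarbazide step, chlorophenyl to methylphenyl

A few compounds are considered here, and "the series" means these few. Any claim that something is new, unique, unknown or untested is made for them only; others in the source may bear on it.

Measured in a functional assay on KB cells (Homo sapiens) for cytotoxicity, read by MTT assay, with a stated time of 72 h (a lower number here means a stronger inhibitor, a higher number a weaker inhibitor), so far:
compound 1 `O=C(NC(=S)NNc1ncnc2ccccc12)c1ccccc1F` gives 2510 nM;
compound 2 `COc1cc2ncnc(NNC(=S)NC(=O)c3ccccc3Cl)c2cc1OC` gives 3560 nM;
compound 3 `COc1cc2ncnc(NNC(=S)NC(=O)c3ccccc3F)c2cc1OC` gives 4070 nM.

Going by the values given here, compound 2 sits among the three numbers with no step to either neighbour beyond the scatter: compound 3 is its nearest, compound 1 the furthest, and both gaps are within the scatter. Compound 4 `COc1cc2ncnc(NNC(=S)NC(=O)c3ccc(C)cc3)c2cc1OC` is not yet measured; it differs from compound 2 by 4-methylphenyl in place of 2-chlorophenyl on a carbonyl carbon. Among the compounds with values here, the only measured step that touches the carbonyl-bound ring is a 1.1-fold higher number from compound 2 to compound 3 (0.06 log units; within the scatter), which is within the scatter. Within the data shown here, no step swaps a halogen for a methyl, nor moves a substituent across the ring, so the change from compound 2 to compound 4 is only loosely covered. For compound 4 the expected step is a 1.1-fold higher number from compound 2 to compound 4 (0.05 log units; within the scatter), which is within the scatter. Compound 4 is therefore estimated at 4000 nM with a range of 1800 nM to 9000 nM in this assay.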

Compound 4, half-maximal inhibitory concentration: 24200 nM
The estimate for compound 4 lay 6.1-fold (0.78 log units) below the measured number; the measured number lies above the stated range.
By their numbers in this assay, from the lowest: compounds 1, 2 and 3 (each within the scatter of the next); then compound 4.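

On the carbonyl carbon, the aryl group affects the result in this assay: 4-methylphenyl in place of 2-chlorophenyl gives a 6.8-fold higher number from compound 2 to compound 4 (0.83 log units; beyond the scatter), and in place of 2-fluorophenyl it gives a 5.9-fold higher number from compound 3 to compound 4 (0.77 log units; beyond the scatter). Going by these compounds alone, these are the first steps beyond the scatter at this position, both towards weaker inhibition, whereas the halogen exchange gave only a 1.1-fold higher number from compound 2 to compound 3 (0.06 log units; within the scatter). No measurement at hand accounts for this loss.

Compound 4 differs from compound 2 in both the substituent and its location on the ring, and these two changes cannot be separated here. From the compounds shown here alone, how an amino group or a carboxylic acid on this ring would behave also remains open.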